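The compounds below may be only part of what the source reports. "The series", "measured", "known", "first", "only" and "open" are said of these compounds alone.

Measured so far in a functional assay on U-251 cells (Homo sapiens) for antiproliferative activity, read by MTT assay, with a stated time of 72 h; on this read-out higher numbers stand for weaker inhibition and lower numbers for stronger inhibition:
- compound 1 `Cc1nc(C(=O)Nc2ccc(Cl)c(-c3nnc4c(Cl)cccn34)c2)cs1`: 74300 nM
- compound 2 `O=C(Nc1ccc(Cl)c(-c2nnc3c(Cl)cccn23)c1)c1ccc(Cl)cc1Cl`: > 100000 nM

Compound 2 stands at the edge of what this assay reports. Its value of > 100000 nM is a limit of the assay, not a number (the limit of > 100000 nM in this assay, at which 1 of the 2 values shown sits). For the measured compounds named here, compound 1 carries 2-methyl-1,3-thiazol-4-yl on the carbonyl carbon and does give a number in this assay, and the step of an at least 1.3-fold higher number from compound 1 to compound 2 (0.12 log units; that floor lies within the scatter) is the only measured change at that position.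

Compound 3 `O=C(Nc1ccc(Cl)c(-c2nnc3c(Cl)cccn23)c1)c1ccon1` differs from compound 2 as follows: 1,2-oxazol-3-yl in place of 2,4-dichlorophenyl on a carbonyl carbon. Going by the values given here, this returns a five-membered aromatic ring to the carbonyl carbon, much as in compound 1, so the one measured step bears on it in reverse: the change to 2,4-dichlorophenyl gave a higher number, and the change back to a small heteroaryl is expected to give a lower one, though the measured step itself lies within the scatter. The expected shift an at least 1.2-fold lower number from compound 2 to compound 3 (0.09 log units; that floor lies within the scatter) is therefore small and downward, with a real chance that compound 3 also sits at the limit.

Compound 3 is estimated at 80000 nM in this assay, with a range from 30000 nM to 200000 nM.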

Compound 3, half-maximal inhibitory concentration: > 100000 nM
Compound 3 ended at the assay's limit; the forecaster's own chance of this, stated with the estimate: 40%; at least 1.2-fold (0.09 log units) between middle value and limit.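

In this assay compound 3 gives a limit, not a number, as compound 2 does, so the step between these two cannot be read: the limit of > 100000 nM in this assay, at which 2 of the 3 values shown sit.

For the compounds shown here, the one readable step for this change at the carbonyl carbon is an at least 1.3-fold higher number from compound 1 to compound 3 (0.12 log units; that floor lies within the scatter). Compound 3 adds a point the earlier compounds could not give: a five-membered aromatic ring on the carbonyl carbon is not enough on its own to give a number, since 1,2-oxazol-3-yl ends at the limit, and among the three groups shown only 2-methyl-1,3-thiazol-4-yl in compound 1 gives one.

Compound 1 gives 74300 nM. Left open is whether any other group on the carbonyl carbon, for instance a piperidine or a carboxylic acid, takes the number clearly lower. Also open, from the compounds shown here alone, is how much of this read-out follows the group on the carbonyl carbon and how much follows the shared core, which is the same in all three compounds.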